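This account rests on a few compounds, and the source may have more. Where it says the series, first, only, none or still open, it means among the compounds named here.

Compound 1 `Cc1ccc(-n2cc(NC(=O)c3cccc(NS(=O)(=O)c4ccc(Cl)cc4)c3)cn2)cc1` was tested in a functional assay on HeLa cells (Homo sapiens) for inhibition, read by MTT assay, with a stated time of 48 h (a higher number here means a weaker inhibitor, a lower number a stronger inhibitor), where compound 1 gives 4570 nM. Compound 2 `COc1ccc(-n2cc(NC(=O)c3cccc(NS(=O)(=O)c4ccc(Cl)cc4)c3)cn2)cc1` carries the change methoxy in place of methyl on an aromatic carbon and, in this assay, compound 2 gives 19700 nM, a step of a 4.3-fold higher number from compound 1 to compound 2 (0.63 log units; beyond the scatter). Compound 3 `Cc1ccc(-n2cc(NC(=O)c3ccc(NS(=O)(=O)c4ccccc4)cc3)cn2)cc1` rests on a different core; the difference between the two cores is not broken down here. In this assay compound 3 gives 27900 nM. Compound 4 `COc1ccc(-n2cc(NC(=O)c3ccc(NS(=O)(=O)c4ccccc4)cc3)cn2)cc1` arises from compound 3 by the same change, (methoxy in place of methyl on an aromatic carbon), at a place described in the same words. Among the measured compounds shown here, only one earlier instance of this change exists, so the expectation for compound 4 rests on the step of a 4.3-fold higher number from compound 1 to compound 2 (0.63 log units; beyond the scatter) alone and is held loosely. Compound 4 is expected to show a step of about a 2.7-fold higher number from compound 3 to compound 4 (0.43 log units; beyond the scatter). The estimate for compound 4 is 75000 nM, expected to lie between 25000 nM and 200000 nM.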

Compound 4, half-maximal inhibitory concentration: 47200 nM
Compound 4: middle estimate off by 1.6-fold (0.20 log units), on the high side; measured number inside the range.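

In this assay, methoxy in place of methyl on the core of compound 3 gives a 1.7-fold higher number from compound 3 to compound 4 (0.23 log units; within the scatter), and this step lies within the scatter, unlike the earlier step on the core of compound 1. Even so, the two steps cannot be told apart: the same change on two cores in this assay, a 4.3-fold higher number (0.63 log units; beyond the scatter) from compound 1 to compound 2 and a 1.7-fold higher number (0.23 log units; within the scatter) from compound 3 to compound 4, 2.5-fold (0.41 log units) apart, within the scatter of two such steps. This shows that the results fit a change that carries from one core to the other, but with one pair on each core it does not establish a shared step size or show that the step on the core of compound 3 is real.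

The compounds shown leave open how an amine, a carboxylic acid or a longer chain such as ethoxy would read at the same place on the ring. No pair shown separates the parts of the difference between the two cores.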